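Trimethoxy anilide series: a pyridyl replaces the biphenyl

A few compounds are considered here, and "the series" means these few. Any claim that something is new, unique, unknown or untested is made for them only; others in the source may bear on it.

Measured compounds:
Compound 1, `CCCCCCCCCCCCn1nnc(C(C(=O)NC(C)(C)C)c2ccccc2)n1`, 3350 nM
Compound 2, `CCCCCCCCCCCCn1nnc(C(C(=O)Nc2c(OC)cc(OC)cc2OC)c2ccc(-c3ccccc3)cc2)n1`, 221 nM

In an assay on liver for inhibition of sterol O-acyltransferase 1 (Rattus norvegicus), using microsomes (on this read-out higher numbers stand for weaker inhibition and lower numbers for stronger inhibition), compound 2 gives 221 nM, the lowest of the two numbers recorded; compound 1 gives 3350 nM, a markedly higher number, beyond the usual scatter. Going by the values given here, the two compounds differ in more than one place, so no single step between them can be assigned.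

Compound 3, `CCCCCCCCCCCCn1nnc(C(C(=O)Nc2c(OC)cc(OC)cc2OC)c2ccccn2)n1`, has not yet been measured in this assay. It keeps the rest of compound 2 and differs from it in one place: pyridin-2-yl in place of 4-phenylphenyl on a saturated chain carbon bound to an aromatic carbon and a carbonyl carbon.

Among the compounds with values here, no single-change step toward compound 3 is available among the measured pairs. Compound 3 is expected to give a higher number than compound 2, with the step from a 6.8-fold higher number from compound 2 to compound 3 (0.83 log units; beyond the scatter) estimated as larger than the scatter, given that the smaller aryl in compound 1 sits at 3350 nM. The estimate for compound 3 is 1500 nM, within a range from 400 nM to 6000 nM.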

Compound 3, half-maximal inhibitory concentration: 590 nM
Compound 3: middle estimate off by 2.5-fold (0.41 log units), on the high side, within the range that was stated.
By their numbers in this assay, from the lowest: compound 2; then compound 3; then compound 1.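

In this assay, going by these compounds alone, the step of a 2.7-fold higher number from compound 2 to compound 3 (0.43 log units; beyond the scatter) gives the first single-change reading at this position, on a saturated chain carbon bound to an aromatic carbon and a carbonyl carbon. Pyridin-2-yl, with one six-membered aromatic ring and a hydrogen-bond acceptor, replaces the two carbon-only rings of 4-phenylphenyl at only a modest loss, so in this anilide the larger group is not essential for inhibition. Nothing shown gives a reason for this step.

On these data alone, it remains open how much of the step belongs to losing the outer phenyl ring and how much to the ring nitrogen, which a pyridin-3-yl or a pyridin-4-yl group at this place would help to separate. As far as these compounds go, it is also open whether the step would hold with a shorter chain in place of the dodecyl chain.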